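The source may report more compounds than this note shows. Statements on the series, on what has been measured and on what is new or still open speak of the compounds shown alone.

Measured in a functional assay on A2780 cells (Homo sapiens) for inhibition, read by sulforhodamine B assay, with a stated time of 72 h; on this read-out lower numbers stand for stronger inhibition and higher numbers for weaker inhibition:
- compound 1 `O=C(NCc1ccc(S(=O)(=O)c2cccc(F)c2)cc1)c1cc2cnccc2[nH]1`: 11 nM
- compound 2 `O=C(NCc1ccc(S(=O)(=O)N2CCCCC2)cc1)c1cc2cnccc2o1`: 1500 nM
- compound 3 `O=C(NCc1ccc(S(=O)(=O)c2ccccc2)cc1)c1cc(-c2cccnc2)[nH]n1`: > 10000 nM, a limit of the assay and not a number

Of the two true numbers, the higher belongs to compound 2 at 1500 nM and the lower to compound 1 at 11 nM. The gap between these two compounds lies beyond the scatter. Compound 4 `O=C(NCc1ccc(S(=O)(=O)N2CCCCC2)cc1)c1ccn2ccnc2c1` departs from compound 2 on the carbonyl carbon: a group of 9 heavy atoms (7 carbon, 2 nitrogen; one five-membered aromatic ring with 2 hetero atoms, one six-membered aromatic ring with 1 hetero atom) in place of a group of 9 heavy atoms (7 carbon, 1 nitrogen, 1 oxygen; one five-membered aromatic ring with 1 hetero atom, one six-membered aromatic ring with 1 hetero atom), on a carbonyl carbon. For the measured compounds named here, no measured pair shows this kind of exchange, so the expectation rests on compound 2 alone and stays uncertain in both directions. In this assay, no step beyond the scatter is expected, with the middle of the estimate set slightly on the weaker side: a 1.3-fold higher number from compound 2 to compound 4 (0.12 log units; within the scatter). The estimated value for compound 4 is 2000 nM, with an expected range of 250 nM to 10000 nM.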

Compound 4, half-maximal inhibitory concentration: > 10000 nM
Compound 4: no number, only a limit; the forecaster's own chance of this, stated with the estimate: 15%; middle value at least 5.0-fold (0.69 log units) from the limit.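

For the compounds shown here, the group on the carbonyl carbon is the first place where a one-place change can be read, and in this assay the five-membered aromatic ring with 2 hetero atoms in place of the one with 1 hetero atom gives an at least 6.6-fold higher number from compound 2 to compound 4 (0.82 log units; beyond the scatter). Compound 4 at > 10000 nM gives a limit of the assay and not a number, so the step has a floor but no upper end. That limit recurs within this small set: the limit of > 10000 nM in this assay, at which 2 of the 4 values shown sit.

Open, going by these compounds, is whether an amine or a methoxy group on this ring system would alter the outcome. Also open, on these data alone, is whether the same exchange behaves alike with the remainder of compound 1.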